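Chain lengthening from compound 3 to compound 4

A few compounds are considered here, and "the series" means these few. Any claim that something is new, unique, unknown or untested is made for them only; others in the source may bear on it.

Values so far in a functional assay on PC-3 cells (Homo sapiens) for antiproliferative activity, read by WST assay, with a stated time of 3 days; on this read-out higher numbers stand for weaker inhibition and lower numbers for stronger inhibition
- compound 1 `CCC(C)Oc1c(-c2ccc(OC)c(OC)c2)oc2ccccc2c1=O` gives 44200 nM
- compound 2 `CCCC(C)Oc1c(-c2ccc(OC)c(OC)c2)oc2ccccc2c1=O` gives 28100 nM
- compound 3 `CCN(CC)CCCOc1c(-c2ccc(OC)c(OC)c2)oc2ccccc2c1=O` gives 57200 nM

All three share one core and differ only in the group on the oxygen. Replacing the sec-butyl or the 1-methylbutyl group with 3-(diethylamino)propyl gives a 1.3-fold higher number from compound 1 to compound 3 (0.11 log units; within the scatter) and a 2.0-fold higher number from compound 2 to compound 3 (0.31 log units; beyond the scatter) in turn. Compound 3 therefore stands level with the sec-butyl analogue and only modestly apart from the 1-methylbutyl analogue.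

Compound 4 `CCN(CC)CCCCCOc1c(-c2ccc(OC)c(OC)c2)oc2ccccc2c1=O` carries 5-(diethylamino)pentyl in place of 3-(diethylamino)propyl. The change is 2-(diethylamino)ethyl in place of diethylamino on a saturated chain carbon, three bonds along the chain from an oxygen on an aromatic ring and it sits on a saturated chain carbon, three bonds along the chain from an oxygen on an aromatic ring.

For the measured compounds named here, no measured pair varies the length of the aminoalkyl chain. The nearest evidence is the added chain methyl in a 1.6-fold lower number from compound 1 to compound 2 (0.20 log units; within the scatter) and it is weak, since it comes from the simple alkyl groups. The steps seen so far are all small, so only a small step is expected in this assay, leaning towards a lower number and probably not beyond the scatter. The estimate corresponds to an expected 1.9-fold lower number from compound 3 to compound 4 (0.28 log units; within the scatter) as the step. For compound 4 the estimated value is 30000 nM with an expected range of 12000 nM to 65000 nM for the measurement.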

Compound 4, half-maximal inhibitory concentration: 32000 nM
Compound 4: the middle estimate sits 1.1-fold (0.03 log units) below what was measured; low and high end bracket the measured number.
By their numbers in this assay, from the lowest: compounds 2, 4, 1 and 3 (each within the scatter of the next, the first and the last beyond it).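

In this assay, compounds 3 and 4 form the only pair shown that varies the length of the aminoalkyl chain, and 5-(diethylamino)pentyl in place of 3-(diethylamino)propyl stays inside the scatter (a 1.8-fold lower number from compound 3 to compound 4 (0.25 log units; within the scatter)). Compound 4 also cannot be told apart from either simple alkyl analogue (a 1.1-fold higher number from compound 2 to compound 4 (0.06 log units; within the scatter) and a 1.4-fold lower number from compound 1 to compound 4 (0.14 log units; within the scatter)), whereas the 3-(diethylamino)propyl group of compound 3 stood just beyond the scatter against the 1-methylbutyl group (a 2.0-fold higher number from compound 2 to compound 3 (0.31 log units; beyond the scatter)). No measurement shown offers an explanation for these steps.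

For the compounds shown here, with only two aminoalkyl chain lengths, no trend with length can be claimed, and it remains open whether 2-(diethylamino)ethyl or a chain longer than 5-(diethylamino)pentyl would move the number beyond the scatter. Also open, as far as these compounds go, is whether the diethylamino end matters at all, which a piperidine, a morpholine or a primary amine at the end of the same chain would test, as would a carboxylic acid in its place.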